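Swapping a cyclopentyl ether for a pyrazolyl-ethyl ether

The compounds below may be only part of what the source reports. "The series", "measured", "known", "first", "only" and "open" are said of these compounds alone.

Measured compounds:
- compound 1, `Cc1nn(-c2ncnc3nc[nH]c23)c2c1C(OC1CCCC1)CC(=O)N2`: 62 nM
- compound 2, `Cc1nn(-c2ncnc3nc[nH]c23)c2c1C(OCc1cc(F)cc3c1OCOC3)CC(=O)N2`: 30 nM

In a functional assay on HEK293 cells for agonist activity at G-protein coupled receptor 39 (Homo sapiens), read by scintillation proximity assay and inositol phosphate accumulation, with a stated time of 75 min (a lower number here means that less compound is needed, a higher number that more compound is needed for the effect), compound 1 gives 62 nM, the highest of the two numbers; compound 2 gives 30 nM, a step beyond the scatter. Compound 3, `Cc1nn(-c2ncnc3nc[nH]c23)c2c1C(OCCn1nccc1C)CC(=O)N2`, differs from compound 1 at an oxygen on a saturated carbon: a group of 8 heavy atoms (6 carbon, 2 nitrogen; one five-membered aromatic ring with 2 hetero atoms) in place of a group of 5 heavy atoms (5 carbon; one five-membered non-aromatic ring of carbon only), on an oxygen on a saturated carbon. For the measured compounds named here, with no measured step of this kind, the expectation rests on compound 2 alone, where a larger aromatic ether gave 30 nM. A small step down or none beyond the scatter is expected, a 1.4-fold lower number from compound 1 to compound 3 (0.14 log units; within the scatter). Compound 3 is estimated at 45 nM, between 15 nM and 150 nM.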

Compound 3, half-maximal effective concentration: 1620 nM
For compound 3 the middle estimate is 36-fold (1.56 log units) below the measured one, and the stated range ends below it.
By their numbers in this assay, from the lowest: compound 2; then compound 1; then compound 3.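

The group on this oxygen matters far more than compound 1 and compound 2 alone suggested: in this assay, replacing cyclopentyl gives a 26-fold higher number from compound 1 to compound 3 (1.42 log units; beyond the scatter), and the other comparison gives a 54-fold higher number from compound 2 to compound 3 (1.73 log units; beyond the scatter). Heavy-atom count does not order these numbers, as the group in compound 3 is larger than cyclopentyl yet smaller than the group in compound 2, and both steps go up. No measurement here explains this loss.

Compound 3 changes both the chain and the ring, so which part accounts for the loss remains open. A phenylethyl group, with only carbon in its ring, would help separate the two.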